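The source may report more compounds than this note shows. Statements on the series, on what has been measured and on what is new or still open speak of the compounds shown alone.

For the measured compounds named here, compound 2 `CN(CCN1CCCCC1)c1ccc(C(=O)N2CCc3ccc(OS(N)(=O)=O)cc3C2)cc1` gives the lower of the two numbers so far in an assay on HEK293 cells for inhibition of Steryl-sulfatase (Homo sapiens), tested at 1 uM (a higher number here means a stronger effect of the compound at the concentration tested, a lower number a weaker effect), 26.8%, while compound 1 `CCN(Cc1ccncc1)c1ccc(C(=O)N2CCc3ccc(OS(N)(=O)=O)cc3C2)cc1` gives 86.6%. Going by the values given here, the one step seen, a number 59.8 percentage points lower from compound 1 to compound 2 (beyond the scatter), bears directly on compound 3 `CCN(Cc1ccccc1)c1ccc(C(=O)N2CCc3ccc(OS(N)(=O)=O)cc3C2)cc1`, which differs from compound 2 by benzyl(ethyl)amino in place of methyl(2-(piperidin-1-yl)ethyl)amino on an aromatic carbon. Among the compounds with values here, since the group entering in compound 3 resembles the group left behind in compound 1 more than the one in compound 2, a large rise is expected, roughly reversing a number 59.8 percentage points lower from compound 1 to compound 2 (beyond the scatter), so that a number 57.2 percentage points higher from compound 2 to compound 3 (beyond the scatter) is the expected step. Compound 3 is therefore estimated at 84%, within 62% to 97%.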

Compound 3, a percentage reported as inhibition, at one concentration (the size of the read-out at that concentration, not a potency): 83.6%
The estimate for compound 3 lay 0.4 percentage points above the measured number; the range from low to high includes it.
By their numbers in this assay, from the lowest: compound 2; then compounds 3 and 1 (each within the scatter of the next).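

In this assay, benzyl(ethyl)amino in place of methyl(2-(piperidin-1-yl)ethyl)amino gives a number 56.8 percentage points higher from compound 2 to compound 3 (beyond the scatter) on this aromatic carbon, so the low number of compound 2 does not extend to every group of this size here. Phenyl in place of pyridin-4-yl gives a number 3 percentage points lower from compound 1 to compound 3 (within the scatter) and thus no distinguishable change, so the pyridine nitrogen is not required for a high number in this series. Nothing available explains either step.

Going by these compounds, it remains open whether the piperidine ring, the two-carbon chain or the methyl on nitrogen accounts for the low number of compound 2. A morpholine on that chain, or benzyl(methyl)amino at this position, would help separate these.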